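The source may hold more compounds than are shown below. What is called first, only, known or untested is meant among the compounds shown, and "the series" means these compounds.

Compound 1, with the structure `COc1cc(C)cc(-c2c(-c3ccnc(-c4ccc(C(C)=O)cc4)c3)cnn2CC#N)c1`, belongs to a set of three compounds tested in a functional assay on CCRF-CEM cells (Homo sapiens) for cytotoxicity, read by sulforhodamine B assay, with a stated time of 48 h, tested at 10 uM; on this read-out higher numbers stand for a weaker effect at the one concentration tested and lower numbers for a stronger effect. In this assay compound 1 gives 14%. Its closest companion is compound 2, `COc1cc(C)cc(-c2nn(CC#N)cc2-c2ccc(-c3cccc(C(C)=O)c3)nc2)c1`, which in this assay gives 12%; the two numbers lie within the usual scatter of each other. Compound 3, `Cc1cc(O)cc(-c2nn(CC#N)cc2-c2ccnc(-c3ccc(N(C)C)cc3)c2)c1`, gives 7% in this assay, again within the scatter of compound 1. So the three measured compounds cannot be told apart on these numbers; all three leave only a small fraction of the cells alive at the concentration tested.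

The unmeasured compound 4 has the structure `COc1cc(C)cc(-c2c(-c3ccnc(-c4ccc(N(C)C)cc4)c3)cnn2CC#N)c1`. It differs from compound 1 in a single place: dimethylamino in place of acetyl on an aromatic carbon. Among the measured compounds shown here, compound 3 already carries a dimethylamino group on a phenyl ring in a similar position, and its value in this assay sits within the scatter of compound 1, although compound 3 also differs from compound 1 in a second place, so no clean step is available.

With nothing pointing either way, the step from compound 1 to compound 4 is expected to be a number 3 percentage points lower from compound 1 to compound 4 (within the scatter), that is, no change beyond the scatter. Compound 4 is therefore estimated to give 11% in this assay, with a range from 3% to 20%.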

Compound 4, a percentage reported as activity, at one concentration (the size of the read-out at that concentration, not a potency): 8%
Beside the measured number, compound 4's estimate is 3 percentage points above it, and the stated range covers the measured number.
By their numbers in this assay, from the lowest: compounds 3, 4, 2 and 1 (each within the scatter of the next).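

Among the compounds shown here, the swap from 4-acetylphenyl to 4-(dimethylamino)phenyl gives the first clean one-place comparison in this set: in this assay, the change is a number 6 percentage points lower from compound 1 to compound 4 (within the scatter). On an aromatic carbon of this six-membered ring, para to a large group, the carbonyl of the acetyl group can therefore give way to the nitrogen of dimethylamino, with the same count of heavy atoms, without any change beyond the scatter at the one concentration tested. No independent measurement is available to say what lies behind this result.

As far as these compounds go, a single step between two groups cannot show how much freedom this position allows in general, so it remains open whether a carboxylic acid, a primary amine or a longer chain such as diethylamino would leave the read-out equally low. From the compounds shown here alone, since the read-out comes from one concentration and is not a potency, it also remains open whether compound 1 and compound 4 would stay indistinguishable across a range of lower concentrations.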